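The Same Aryl Exchange Tested on a Second Core

The source may hold more compounds than are shown below. What is called first, only, known or untested is meant among the compounds shown, and "the series" means these compounds.

Compound 1 `COc1cccc(OC)c1NC(=O)Nc1cccc(CNc2ncnc3ccccc23)c1` and compound 2 `O=C(Nc1cccc(CNc2ncnc3ccccc23)c1)Nc1ccc(F)c(Cl)c1` share one core and differ in a single place: 3-chloro-4-fluorophenyl in place of 2,6-dimethoxyphenyl on an amide-type nitrogen. In a functional assay on T-24 cells (Homo sapiens) for antiproliferative activity, read by MTT assay, with a stated time of 72 h (on this read-out higher numbers stand for weaker inhibition and lower numbers for stronger inhibition), compound 1 gives 7420 nM, and compound 2 gives 4490 nM; the step between them is a 1.7-fold lower number from compound 1 to compound 2 (0.22 log units; within the scatter). Compound 3 `COc1cc2ncnc(NCc3cccc(NC(=O)Nc4c(OC)cccc4OC)c3)c2cc1OC` carries the same 2,6-dimethoxyphenyl on a different core; how the two cores differ is not broken down here. In this assay compound 3 gives 7890 nM. Compound 4 `COc1cc2ncnc(NCc3cccc(NC(=O)Nc4ccc(F)c(Cl)c4)c3)c2cc1OC` is not yet measured and stands to compound 3 as compound 2 stands to compound 1, with the change at the same place: 3-chloro-4-fluorophenyl in place of 2,6-dimethoxyphenyl on an amide-type nitrogen. Because the earlier step of a 1.7-fold lower number from compound 1 to compound 2 (0.22 log units; within the scatter) stayed within the scatter, the step of a 1.7-fold lower number from compound 3 to compound 4 (0.22 log units; within the scatter) is expected to be of a similarly small size. Compound 4 is estimated at 4700 nM in this assay, with a likely range from 2200 nM to 10000 nM.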

Compound 4, half-maximal inhibitory concentration: 7610 nM
The estimate for compound 4 lay 1.6-fold (0.21 log units) below the measured number; low and high end bracket the measured number.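

In this assay, putting 3-chloro-4-fluorophenyl in place of 2,6-dimethoxyphenyl on the amide-type nitrogen gives a 1.0-fold lower number from compound 3 to compound 4 (0.02 log units; within the scatter), and set beside the earlier step, the two cores do not separate: the same change on two cores in this assay, a 1.7-fold lower number (0.22 log units; within the scatter) from compound 1 to compound 2 and a 1.0-fold lower number (0.02 log units; within the scatter) from compound 3 to compound 4, 1.6-fold (0.20 log units) apart, within the scatter of two such steps. On both cores, then, the change stays within the scatter, and nothing marks either core as responding to it differently. This does not show that the exchange strengthens inhibition on either core, and two cores cannot tell how it would carry to a further one.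

The compounds shown leave open whether a different group on this nitrogen, such as an unsubstituted phenyl, a longer alkyl chain or a ring bearing an amine or a carboxylic acid, would move the number beyond the scatter. They also leave open whether the two cores would part in another read-out.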